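The source may hold more compounds than are shown below. What is called first, only, known or untested is meant among the compounds shown, and "the series" means these compounds.

Compound 1 `COc1cc(CNC(=O)c2cc3nc(C)c([C@H](OC(C)(C)C)C(=O)O)c(-c4cc(F)c5c(c4C)CCCO5)n3n2)ccc1F` in an ADME assay on MT2 cells (Homo sapiens) for cytotoxicity (a higher number here means that more compound is tolerated, a lower number that less compound is tolerated), gives > 20000 nM, which is a limit of the assay and not a number.
Compound 2 `Cc1nc2cc(C(=O)NCc3ccc(F)cc3S(C)(=O)=O)nn2c(-c2cc(F)c3c(c2C)CCCO3)c1[C@H](OC(C)(C)C)C(=O)O` in this assay gives > 40000 nM, likewise a limit.
Compound 3 `Cc1nc2cc(C(=O)NCc3ccc(F)cc3N3CCCC3=O)nn2c(-c2cc(F)c3c(c2C)CCCO3)c1[C@H](OC(C)(C)C)C(=O)O` in this assay gives > 40000 nM, likewise a limit.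

Compound 2 therefore stands at a limit rather than at a measured number, and the two other values shown are limits as well: two of the three sit at the limit of > 40000 nM in this assay, at which 2 of the 3 values shown sit, and one at the limit of > 20000 nM in this assay, at which 1 of the 3 values shown sits. Compound 4 `Cc1nc2cc(C(=O)NCCC3CCCCC3)nn2c(-c2cc(F)c3c(c2C)CCCO3)c1[C@H](OC(C)(C)C)C(=O)O` has not yet been measured. The change from compound 2 to compound 4 is cyclohexylmethyl in place of 4-fluoro-2-(methylsulfonyl)phenyl on a saturated chain carbon bound to an amide-type nitrogen. For the measured compounds named here, two measured steps touch the same place on the shared core, the group on a saturated chain carbon bound to an amide-type nitrogen: the step that the two limits leave unreadable from compound 1 to compound 2 and the step that the two limits leave unreadable from compound 2 to compound 3. Neither can be read in size, since both ends of each are limits, so they show only that none of the three groups tried there brought the value down to a measurable number. On that basis no step beyond the scatter is expected in this assay, and the step of a number no higher from compound 2 to compound 4 (the limit leaves the size open) is expected to be small. Compound 4 is estimated at 40000 nM, with a range from 15000 nM to 100000 nM, most likely reported again as a limit.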

Compound 4, half-maximal cytotoxic concentration: > 40000 nM
Compound 4: no number, only a limit; the forecaster's own chance of this, stated with the estimate: 80%; the middle value sits exactly at the limit.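

Compound 4, like compound 1 and compound 2, stands at a limit of this assay and not at a number, so neither of its steps from those two compounds can be read in size. The compounds shown leave open the actual tolerated concentration of all four compounds, and whether any group on that saturated chain carbon would give a measurable value.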